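Removing a methoxy group: cytotoxicity on THP-1 cells

A few compounds are considered here, and "the series" means these few. Any claim that something is new, unique, unknown or untested is made for them only; others in the source may bear on it.

Measured compounds:
Compound 1, `Cn1c(-c2cccc(C#N)c2)cnc1NC(=O)c1ccc(F)cc1`, in a toxicity assay on THP-1 cells (Homo sapiens) for inhibition (a higher number here means that more compound is tolerated, a lower number that less compound is tolerated), gives the limit > 100000 nM.
Compound 2, `COc1ccc(-c2cnc(NC(=O)c3ccccc3OC)n2C)cc1`, gives the limit > 100000 nM.
Compound 3, `COc1ccc(-c2cnc(NC(=O)c3ccc(F)cc3)[nH]2)cc1`, gives the limit > 100000 nM.

None of these three values is a number; each is a limit, the highest concentration tested, at which no half-maximal toxicity was reached. Compound 2 therefore stands where every measured compound stands, at the top of the tested range, and nothing here separates it from compound 1 or compound 3.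

The unmeasured compound 4, `COc1ccc(-c2cnc(NC(=O)c3ccccc3)n2C)cc1`, differs from compound 2 in one place:

hydrogen in place of methoxy on an aromatic carbon

No change between measured compounds is available to say how much such a change moves toxicity. Because (the limit of > 100000 nM in this assay, at which 3 of the 3 values shown sit), the step of a number no higher from compound 2 to compound 4 (the limit leaves the size open) is expected to be none beyond the scatter, and most likely compound 4 will again return a limit rather than a number. Compound 4 is estimated at 100000 nM, with a range from 50000 nM to 200000 nM.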

Compound 4, half-maximal cytotoxic concentration: > 100000 nM
Compound 4: only a limit was reported (the forecaster's own chance of this, stated with the estimate: 85%); the middle value lies on the limit itself.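

The step from compound 2 to compound 4 cannot be read, since both compounds give only a limit and not a number: the limit of > 100000 nM in this assay, at which 4 of the 4 values shown sit.

What stays open is how much of any of these compounds it takes to reach half-maximal toxicity in this assay and whether removing the methoxy group moves that amount at all.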